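Swapping One Methyl for Hydrogen in a Cytotoxicity Test

The source may hold more compounds than are shown below. What is called first, only, known or untested is meant among the compounds shown, and "the series" means these compounds.

In a functional assay on OE21 cells (Homo sapiens) for cytotoxicity, read by MTT assay, with a stated time of 72 h (on this read-out lower numbers stand for stronger inhibition and higher numbers for weaker inhibition), compound 1 `COc1ccc2[nH]c(-c3ccc[nH]3)cc2c1` gives 33000 nM. In the same test compound 2 `Cc1ccc2[nH]c(-n3cccn3)c(C3=C(Br)C(=O)NC3=O)c2c1` gives 28000 nM. These two numbers lie within the usual scatter of each other, so compound 2 cannot be ranked against compound 1.

Compound 3 `O=C1NC(=O)C(c2c(-n3cccn3)[nH]c3ccccc23)=C1Br` has not been measured yet. It differs from compound 2 in one place: hydrogen in place of methyl on an aromatic carbon. Hydrogen stands in place of methyl on an aromatic carbon. Among the measured compounds shown here, no measured pair of compounds shows what this change does, so the data offer no direct guide. With nothing pointing either way, no step beyond the scatter is expected in this assay. The expected change is small, a 1.1-fold higher number from compound 2 to compound 3 (0.03 log units; within the scatter), and stays within the scatter. Compound 3 is therefore expected near 30000 nM, with an estimated range from 12000 nM to 70000 nM.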

Compound 3, half-maximal inhibitory concentration: 27000 nM
Compound 3: the middle estimate sits 1.1-fold (0.05 log units) above what was measured; measured number inside the range.
By their numbers in this assay, from the lowest: compounds 3, 2 and 1 (each within the scatter of the next).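

Replacing the methyl with hydrogen on this aromatic carbon, which sits on a six-membered aromatic ring of carbon only within a fused system of two rings, gives no readable change in this assay: the move is a 1.0-fold lower number from compound 2 to compound 3 (0.02 log units; within the scatter) and lies within the scatter. Among the compounds shown here, compounds 2 and 3 form the first measured pair that differs in just one place, so this single swap can now be judged directly rather than estimated. In this test, the methyl at this position makes no difference that can be told apart from ordinary repeat variation.

On these data alone, whether an amine or a carboxylic acid on this same carbon would shift the number beyond the scatter remains open. Nothing available explains why this swap leaves the number where it is.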